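Oxazole series: piperidin-4-yl in place of 4-chlorophenyl

This account rests on a few compounds, and the source may have more. Where it says the series, first, only, none or still open, it means among the compounds named here.

Measured so far in a functional assay on MIA PaCa-2 cells (Homo sapiens) for cytotoxicity, read by MTT assay, with a stated time of 48 h; a lower number here means a stronger inhibitor, a higher number a weaker inhibitor:
- compound 1 `Oc1ccc(-c2nc(-c3c[nH]c4ccccc34)co2)cc1` gives 103000 nM
- compound 2 `c1ccc2c(-c3coc(-c4ccncc4)n3)c[nH]c2c1` gives 38400 nM
- compound 3 `Clc1ccc(-c2nc(-c3c[nH]c4ccccc34)co2)cc1` gives 326000 nM

Compound 3 has the highest number of the three; compound 1 is nearest, compound 2 furthest. Compound 4 `c1ccc2c(-c3coc(C4CCNCC4)n3)c[nH]c2c1` differs from compound 3 in one place: piperidin-4-yl in place of 4-chlorophenyl on an aromatic carbon. For the measured compounds named here, two measured steps bear on it. First, an 8.5-fold higher number from compound 2 to compound 3 (0.93 log units; beyond the scatter), where the ring carrying a nitrogen gave the lower number. Second, a 3.2-fold higher number from compound 1 to compound 3 (0.50 log units; beyond the scatter), where the group with a hydrogen-bond donor gave the lower number. Both point the same way, so a downward step beyond the scatter is expected, a 5.4-fold lower number from compound 3 to compound 4 (0.74 log units; beyond the scatter). Going by the values given here, no measured step has exchanged an aromatic ring for a non-aromatic one, so the size is uncertain. Compound 4 is estimated at 60000 nM, range 15000 nM to 250000 nM.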

Compound 4, half-maximal inhibitory concentration: 230000 nM
The estimate for compound 4 lay 3.8-fold (0.58 log units) below the measured number, and the stated range covers the measured number.
By their numbers in this assay, from the lowest: compound 2; then compound 1; then compounds 4 and 3 (each within the scatter of the next).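

In this assay, a 1.4-fold lower number from compound 3 to compound 4 (0.15 log units; within the scatter) shows that on this aromatic carbon, a non-aromatic ring with a hetero atom and a hydrogen-bond donor does not separate from 4-chlorophenyl. With a 6.0-fold higher number from compound 2 to compound 4 (0.78 log units; beyond the scatter) and a 2.2-fold higher number from compound 1 to compound 4 (0.35 log units; beyond the scatter), both beyond the scatter, neither a ring nitrogen nor a hydrogen-bond donor suffices for the lower number, as piperidin-4-yl carries both. On these data alone, whether a carboxylic acid or an open-chain aminomethyl group here would fall nearer pyridin-4-yl or piperidin-4-yl remains open. No measured property of these groups accompanies this result.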